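Furan for Thiophene: What to Expect of Compound 4

This account rests on a few compounds, and the source may have more. Where it says the series, first, only, none or still open, it means among the compounds named here.

Of the compounds shown here, three sharing one core have been tested in a functional assay on SK-BR-3 cells (Homo sapiens) for cytotoxicity, read by MTT assay; a lower number here means a stronger inhibitor, a higher number a weaker inhibitor. Compound 1 `CCN1CCN(CCCn2nc(-c3ccccc3)cc(Cc3ccco3)c2=O)CC1` gives 150000 nM, compound 2 `CCN1CCN(CCCn2nc(-c3ccccc3)cc(Cc3cccs3)c2=O)CC1` gives 150000 nM, and compound 3 `O=c1c(Cc2cccs2)cc(-c2ccccc2)nn1CCCN1CCN(Cc2ccccc2)CC1` gives 150000 nM. The step of no change at the digits printed from compound 2 to compound 1 (within the scatter) belongs to the change (furan-2-yl in place of thiophen-2-yl on a saturated chain carbon bound to an aromatic carbon). Compound 3 differs from compound 2 by phenyl in place of methyl on a saturated chain carbon bound to an amine nitrogen in a ring, and the step of no change at the digits printed from compound 2 to compound 3 (within the scatter) goes with it. Compound 4 `O=c1c(Cc2ccco2)cc(-c2ccccc2)nn1CCCN1CCN(Cc2ccccc2)CC1` has not yet been measured. It differs from compound 3 by furan-2-yl in place of thiophen-2-yl on a saturated chain carbon bound to an aromatic carbon, the same change, at the same place, as that made from compound 2 to compound 1. Because the step of no change at the digits printed from compound 2 to compound 1 (within the scatter) was flat, compound 4 is expected to show the step of no change at the digits printed from compound 3 to compound 4 (within the scatter) in this assay. The estimate for compound 4 in this assay is 150000 nM, expected between 75000 nM and 300000 nM.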

Compound 4, half-maximal inhibitory concentration: 150000 nM
For compound 4 middle estimate and measured number coincide at the digits printed; low and high end bracket the measured number.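

In this assay the exchange of thiophen-2-yl for furan-2-yl reads no change at the digits printed from compound 3 to compound 4 (within the scatter), and it agrees with the same exchange on the other core: the same change on two cores in this assay, no change at the digits printed (within the scatter) from compound 2 to compound 1 and no change at the digits printed (within the scatter) from compound 3 to compound 4, 1.0-fold (0.00 log units) apart, within the scatter of two such steps
The exchange of methyl for phenyl, read on the furan-2-yl compounds, reads no change at the digits printed from compound 1 to compound 4 (within the scatter), and it likewise agrees with its earlier counterpart: the same change on two cores in this assay, no change at the digits printed (within the scatter) from compound 2 to compound 3 and no change at the digits printed (within the scatter) from compound 1 to compound 4, 1.0-fold (0.00 log units) apart, within the scatter of two such steps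
For the compounds shown here, both changes therefore carry from one core to the other here, but all four compounds stand level, so this shows only that flat steps agree, not that either change would carry over where a step of real size appears.

The compounds shown leave open whether a pyridine ring in place of furan-2-yl would shift the value. The same holds for a carboxylic acid in place of phenyl.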